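Replacing the acid ester of compound 1 with a cinnamyl ether

This account rests on a few compounds, and the source may have more. Where it says the series, first, only, none or still open, it means among the compounds named here.

Compound 1 `Cc1c(C)c2c(c(C)c1OC(=O)CCC(=O)O)CCC(C)(COc1ccc(/C=C3\SC(=O)NC3=O)cc1)O2` is the weakest of three measured compounds in a functional assay on MCF7 cells (Homo sapiens), tested at 5 uM; on this read-out higher numbers stand for a weaker effect at the one concentration tested and lower numbers for a stronger effect: compound 1 gives 98%. The other two sit clearly lower. Compound 2 `CC(C)=CCOc1c(C)c(C)c2c(c1C)CCC(C)(COc1ccc(/C=C3\SC(=O)NC3=O)cc1C)O2` gives 56%, and compound 3 `COc1cc(/C=C2\SC(=O)NC2=O)ccc1OCC1(C)CCc2c(C)c(OCC=C(C)C)c(C)c(C)c2O1` gives 78%. Going by the values given here, the one step between them, a number 22 percentage points higher from compound 2 to compound 3 (beyond the scatter), shows that a small change at the aromatic ring next to the thiazolidinedione can move the number by a clear margin.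

Compound 4 `Cc1c(C)c2c(c(C)c1OC/C=C/c1ccccc1)CCC(C)(COc1ccc(/C=C3\SC(=O)NC3=O)cc1)O2` differs from compound 1 in a single place: 3-phenylprop-2-en-1-yl in place of (2-carboxyethyl)carbonyl on an oxygen on an aromatic ring. Among the compounds with values here, no measured step shares this change, so the only guide is that compound 1, with its acid-bearing ester, stands highest of the three, while compound 2 and compound 3, which carry an alkenyl group on the same oxygen, give lower numbers. Compound 4 also carries an alkenyl group there, so compound 4 is expected to fall between the measured extremes, a step of a number 28 percentage points lower from compound 1 to compound 4 (beyond the scatter) downward from compound 1. The estimate for compound 4 is 70%, within a range from 45% to 95%.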

Compound 4, a percentage reported as activity, at one concentration (the size of the read-out at that concentration, not a potency): 65%
Compound 4: the middle estimate sits 5 percentage points above what was measured; the measured number falls inside the stated range.
By their numbers in this assay, from the lowest: compounds 2 and 4 (each within the scatter of the next); then compound 3; then compound 1.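

In this assay, going by these compounds alone, the swap on this oxygen gives a number 33 percentage points lower from compound 1 to compound 4 (beyond the scatter), and this is the first direct reading of the group at this place, since the only earlier step, between compound 2 and compound 3, concerned an aromatic carbon elsewhere in the molecule. The departing (2-carboxyethyl)carbonyl carries one hydrogen-bond donor and two acceptors, while the entering 3-phenylprop-2-en-1-yl has none of these and brings a six-membered aromatic ring of carbon only, so the read-out clearly responds to what sits on this oxygen. Nothing measured here explains the size or direction of this step.

The compounds shown leave open which part of the change carries the step: the carboxylic acid, the ester link, the double bond or the phenyl ring. A methyl ester in place of the acid, a saturated 3-phenylpropyl chain or a plain benzyl group on the same oxygen would each separate one of these parts from the others.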